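The source may hold more compounds than are shown below. What is called first, only, known or untested is meant among the compounds shown, and "the series" means these compounds.

Compound 1 `COc1ccc(C(=O)/C=C\Nc2ccc(-c3nc4cc(OC)c(OC)c(OC)c4s3)cc2C)cc1O` and compound 2 `COc1ccc(C(=O)/C=C\Nc2ccc(-c3nc4cc(OC)c(OC)c(OC)c4s3)cc2)cc1O` share one core; compound 3 `COc1ccc2nc(-c3ccc(N/C=C\C(=O)c4cc(OC)c(OC)c(OC)c4Br)c(C)c3)sc2c1` and compound 4 `COc1ccc2nc(-c3ccc(N/C=C\C(=O)c4cc(OC)c(OC)c(OC)c4Br)cc3)sc2c1` share another, and the difference between the two cores is not broken down here. In a functional assay on MIA PaCa-2 cells (Homo sapiens) for antiproliferative activity, read by sulforhodamine B assay, with a stated time of 48 h (a lower number here means a stronger inhibitor, a higher number a weaker inhibitor), compound 1 gives 15400 nM, compound 2 gives 32800 nM, and compound 3 gives 23400 nM. The change from compound 1 to compound 2 is hydrogen in place of methyl on an aromatic carbon, and it gave a 2.1-fold higher number from compound 1 to compound 2 (0.33 log units; beyond the scatter). The change from compound 3 to compound 4 is hydrogen in place of methyl on an aromatic carbon; the two are the same kind of change, though the place differs in its printed words, being meta to a large group in the first case and meta to a 6-methoxy-1,3-benzothiazol-2-yl group in the second. For compound 4 a step like the earlier one is expected, namely a 2.1-fold higher number from compound 3 to compound 4 (0.32 log units; beyond the scatter), because compound 3 stands at 23400 nM and the same change gave a 2.1-fold higher number from compound 1 to compound 2 (0.33 log units; beyond the scatter). The estimate for compound 4 is therefore 49000 nM, expected to lie between 24000 nM and 100000 nM.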

Compound 4, half-maximal inhibitory concentration: 14700 nM
Compound 4: middle estimate off by 3.3-fold (0.52 log units), on the high side, and the stated range ends above it.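

In this assay, hydrogen in place of methyl on the aromatic carbon gives a 1.6-fold lower number from compound 3 to compound 4 (0.20 log units; within the scatter), so this pair shows no effect that can be told from assay scatter. Set beside the earlier pair, the step does not carry over from the core of compound 1 to the core of compound 3: the same change on two cores in this assay, a 2.1-fold higher number (0.33 log units; beyond the scatter) from compound 1 to compound 2 and a 1.6-fold lower number (0.20 log units; within the scatter) from compound 3 to compound 4, 3.4-fold (0.53 log units) apart, beyond the scatter of two such steps. With a single pair on each core, this shows that the step cannot be assumed to transfer, but not which difference between the cores sets the two results apart.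

Open, from the compounds shown here alone, is whether fluorine, ethyl or an amine at the same aromatic carbon would separate from hydrogen and methyl on either core. Also open, going by these compounds, is whether the gap between the two steps would persist on further pairs.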